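This account rests on a few compounds, and the source may have more. Where it says the series, first, only, none or still open, it means among the compounds named here.

In a functional assay on MCF7 cells (Homo sapiens) for inhibition, read by MTT assay, with a stated time of 72 h, tested at 50 uM (on this read-out lower numbers stand for less inhibition of growth and higher numbers for more inhibition of growth at the one concentration tested), three compounds have been measured so far. Compound 1 `C=CCc1ccc(OCc2cn(-c3ccc(OC)cc3)nn2)c(O)c1` gives 57.2%, compound 2 `C#CCOc1ccc(CC=C)cc1O` gives 15.8%, and compound 3 `C=CCc1ccc(OCc2cn(-c3ccccc3CO)nn2)c(O)c1` gives 40.4%. Compound 3 therefore stands second highest of the three, beyond the scatter from each of the other two. From the compounds shown here alone, the next compound is compound 4 `C=CCc1ccc(OCc2cn(-c3ccc(Br)cc3)nn2)c(O)c1`, whose value is still unknown. The change is 4-bromophenyl in place of 2-(hydroxymethyl)phenyl on an aromatic nitrogen, with 4-bromophenyl in place of 2-(hydroxymethyl)phenyl on an aromatic nitrogen.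

For the measured compounds named here, only one measured step bears on this place, a number 16.8 percentage points lower from compound 1 to compound 3 (beyond the scatter), which came with 2-(hydroxymethyl)phenyl in place of 4-methoxyphenyl. That step is modest but beyond the scatter. Going by the values given here, compound 2 offers no step at this place, and no measured compound carries 4-bromophenyl. The evidence is therefore indirect. Compound 4 also gives up 2-(hydroxymethyl)phenyl, so a step of similar or somewhat smaller size, in the opposite direction to a number 16.8 percentage points lower from compound 1 to compound 3 (beyond the scatter), is expected in this assay. With a single step as a guide, the expectation remains loose. The expected change is a number 11.6 percentage points higher from compound 3 to compound 4 (beyond the scatter). For compound 4 the estimated value is 52%, with an expected range from 36% to 68%.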

Compound 4, percent growth inhibition at one concentration: 29.1%
For compound 4 the middle estimate is 22.9 percentage points above the measured one; measured number below the stated range.
By their numbers in this assay, from the lowest: compound 2; then compound 4; then compound 3; then compound 1.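

In this assay, the step of a number 11.3 percentage points lower from compound 3 to compound 4 (beyond the scatter) shows that giving up 2-(hydroxymethyl)phenyl on the aromatic nitrogen does not by itself raise the number, so the earlier pair gave a misleading guide to this change. The step of a number 28.1 percentage points lower from compound 1 to compound 4 (beyond the scatter) adds something no earlier comparison offered: two phenyl groups with a single group at the same ring position, bromo and methoxy, give clearly different numbers, so growth inhibition here depends on what that phenyl carries and not merely on a phenyl being present. Nothing shown here accounts for why 4-methoxyphenyl stands above 4-bromophenyl, or why 2-(hydroxymethyl)phenyl falls between them.

The compounds shown leave open whether the gap between compound 1 and compound 4 reflects something particular to methoxy or to bromo, which a plain phenyl, or a phenyl carrying an amine or a carboxylic acid at that ring position, could help to settle. They also leave open whether the number for compound 3 depends on the hydroxymethyl group itself or on where it sits, which 4-(hydroxymethyl)phenyl could separate.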